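Pyrazole nitrogen substitution and antiproliferative read-out in a urea series

This account rests on a few compounds, and the source may have more. Where it says the series, first, only, none or still open, it means among the compounds named here.

Compound 1 `CNC(=O)N1CCCc2ccc(NC(=O)c3cccc(-c4ccn(C)n4)c3)cc21`: 70.5%
Compound 2 `CNC(=O)N1CCCc2ccc(NC(=O)c3cccc(-c4cn[nH]c4)c3)cc21`: 27.9%
Compound 3 `CNC(=O)N1CCCc2ccc(NC(=O)c3cccc(-c4cc[nH]n4)c3)cc21`: 27.3%

Of the compounds shown here, three sharing one core have been tested in a functional assay on MV4-11 cells (Homo sapiens) for antiproliferative activity, with a stated time of 6 days, tested at 1.56 uM; on this read-out lower numbers stand for a weaker effect and higher numbers for a stronger effect at the one concentration tested. Compound 1 gives 70.5%, the highest of the three. Compound 3 stands lowest with 27.3%; its nearest neighbour is compound 2, whose value lies within the scatter of it, as the step of a number 0.6 percentage points lower from compound 2 to compound 3 (within the scatter) shows, while its furthest is compound 1, with a gap well beyond the scatter.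

The unmeasured compound 4 `CNC(=O)N1CCCc2ccc(NC(=O)c3cccc(-c4cnn(S(C)(=O)=O)c4)c3)cc21` arises from compound 3 by the change (1-(methylsulfonyl)-1H-pyrazol-4-yl in place of 1H-pyrazol-3-yl on an aromatic carbon). Going by the values given here, two measured steps bear on it. The step of a number 43.2 percentage points lower from compound 1 to compound 3 (beyond the scatter) shows that replacing the methyl on the pyrazole nitrogen by hydrogen costs a large amount, and the step of a number 42.6 percentage points lower from compound 1 to compound 2 (beyond the scatter) shows a drop of similar size when the methylated 1H-pyrazol-3-yl is exchanged for an unsubstituted 1H-pyrazol-4-yl. Among the compounds with values here, compound 4 again carries a substituent on the pyrazole nitrogen, a methylsulfonyl rather than a methyl, so a recovery toward the level of compound 1 is expected, though no measured step covers a methylsulfonyl directly. Compound 4 is therefore expected to show a step of a number 22.7 percentage points higher from compound 3 to compound 4 (beyond the scatter) upward. Compound 4 is estimated at 50%, within a range from 20% to 80%.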

Compound 4, a percentage reported as inhibition, at one concentration (the size of the read-out at that concentration, not a potency): 1.6%
Compound 4: middle estimate off by 48.4 percentage points, on the high side, and the stated range ends above it.
By their numbers in this assay, from the lowest: compound 4; then compounds 3 and 2 (each within the scatter of the next); then compound 1.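

In this assay, a substituent on the pyrazole nitrogen does not by itself bring the read-out back: placing methylsulfonyl on the nitrogen of the 1H-pyrazol-4-yl group gives a number 26.3 percentage points lower from compound 2 to compound 4 (beyond the scatter), and the comparison with the other unsubstituted pyrazole gives a number 25.7 percentage points lower from compound 3 to compound 4 (beyond the scatter). Against the methylated pyrazole the change comes to a number 68.9 percentage points lower from compound 1 to compound 4 (beyond the scatter), so on this read-out the two nitrogen-substituted compounds lie on opposite sides of the two unsubstituted ones, and the identity of the substituent matters, not merely its presence. No available evidence accounts for this fall, and the data give no reason for it.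

The compounds shown leave open how much of the gap between the methyl and methylsulfonyl compounds belongs to the nitrogen substituent and how much to the attachment of the pyrazole, a question that 1-methyl-1H-pyrazol-4-yl would address directly. They also leave open where an ethyl, an acetyl or a longer chain on that nitrogen would fall between these extremes.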